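Pyridinyl for chlorophenyl on the sulfonyl of an EP2 agonist

A few compounds are considered here, and "the series" means these few. Any claim that something is new, unique, unknown or untested is made for them only; others in the source may bear on it.

Compound 1: `CCCCc1ccc(CN(c2ccccc2CCCC(=O)O)S(C)(=O)=O)cc1`, 103 nM
Compound 2: `CC(C)(C)c1ccc(CN(Cc2cccc(CCC(=O)O)c2)S(=O)(=O)c2ccccc2)cc1`, 0.2 nM
Compound 3: `CC(C)(C)c1ccc(CN(Cc2cccc(CCC(=O)O)c2)S(=O)(=O)c2ccc(Cl)cc2)cc1`, "not determined" (no result reported)
Compound 4: `CC(C)(C)c1ccc(CN(Cc2cccc(CCC(=O)O)c2)S(=O)(=O)c2ccccn2)cc1`, not yet measured

In a functional assay on HEK293 cells for agonist activity at prostaglandin E2 receptor EP2 subtype (Rattus norvegicus), read by cAMP accumulation (a higher number here means that more compound is needed for the effect, a lower number that less compound is needed), compound 1 gives 103 nM, while compound 2 gives 0.2 nM. Compound 3 carries a (4-chlorophenyl)sulfonyl group where compound 2 carries a plain phenylsulfonyl group, but in this assay compound 3 is recorded as "not determined" (no result reported), so its standing can only be inferred from compound 2, the closest measured neighbour.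

The step from compound 3 to compound 4 is pyridin-2-yl in place of 4-chlorophenyl on a sulfonyl sulfur. For the measured compounds named here, no comparable step between measured compounds is available, so its size cannot be read from the data. Given that compound 2, which shares the whole remainder of the structure, gives 0.2 nM, the expectation is that compound 4 stays in the same region, with a step from compound 3 that is small, most likely within the usual scatter or only somewhat beyond it, in either direction.

Compound 4 is therefore expected to give about 0.5 nM in this assay, with a range from 0.1 nM to 5 nM.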

Compound 4, half-maximal effective concentration: 2.3 nM
Compound 4: the middle estimate sits 4.6-fold (0.66 log units) below what was measured; low and high end bracket the measured number.
By their numbers in this assay, from the lowest: compound 2; then compound 4; then compound 1.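

Pyridin-2-yl in place of phenyl on the sulfonyl sulfur gives, in this assay, a 12-fold higher number from compound 2 to compound 4 (1.06 log units; beyond the scatter) and this is the only step at this place that can be read. It shows that the ring on the sulfonyl sulfur is not a silent part of the structure, since this single exchange, with the rest of the molecule unchanged, moves the number beyond the scatter. The change is not ruinous, however, as compound 4 still gives 2.3 nM in this assay and a pyridin-2-yl ring is therefore tolerated at this place, though nothing measured here explains the size of the step.

For the compounds shown here, compound 3 has no reported number, so no step involving it can be read, and the effect of the 4-chlorophenyl group relative to either plain phenyl or pyridin-2-yl remains unknown. The compounds shown also leave open whether the position of the ring nitrogen matters, as a pyridin-3-yl or pyridin-4-yl group would test, and how a thiophen-2-yl ring would compare at this sulfonyl sulfur.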